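This account rests on a few compounds, and the source may have more. Where it says the series, first, only, none or still open, it means among the compounds named here.

Compound 1 `COc1cc(/C=N/NC(=O)CCCc2nc3ccccc3c(=O)[nH]2)ccc1O` gives 236000000 nM in a physicochemical assay, read by spectrophotometry, with a stated time of 30 min; on this read-out higher numbers stand for weaker inhibition and lower numbers for stronger inhibition. Compound 2 `COc1ccc(/C=N/NC(=O)CCCc2nc3ccccc3c(=O)[nH]2)cc1` gives 247000000 nM in this assay. Compound 3 `COc1cc(/C=N/NC(=O)CCc2nc3ccccc3c(=O)[nH]2)ccc1O` gives 204000000 nM in this assay.

Compounds 1 and 3 share much of their structure but carry different cores; the difference between the two cores is not broken down here. On the core of compound 1, the change from compound 1 to compound 2 is 4-methoxyphenyl in place of 4-hydroxy-3-methoxyphenyl on a carbon with a double bond to nitrogen. This step gives a 1.0-fold higher number from compound 1 to compound 2 (0.02 log units; within the scatter), so the two compounds cannot be told apart by this assay. The values of compound 3 and compound 1 are likewise within the usual scatter of each other, as are those of compound 3 and compound 2.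

Compound 4 `COc1ccc(/C=N/NC(=O)CCc2nc3ccccc3c(=O)[nH]2)cc1` has not been measured. It arises from compound 3 by 4-methoxyphenyl in place of 4-hydroxy-3-methoxyphenyl on a carbon with a double bond to nitrogen. The change and its place are the same, word for word, as the change from compound 1 to compound 2, so it is the same change made on the other core.

Because the earlier step gave a 1.0-fold higher number from compound 1 to compound 2 (0.02 log units; within the scatter), the step from compound 3 to compound 4 is expected to be of similar size, a 1.1-fold higher number from compound 3 to compound 4 (0.02 log units; within the scatter), and to stay within the usual scatter. Compound 4 is therefore estimated to give 215000000 nM in this assay. The value of compound 4 is expected to fall between 130000000 nM and 360000000 nM, with the measured values of compound 1 and compound 2 setting the middle of that range.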

Compound 4, half-maximal inhibitory concentration: 214000000 nM
Compound 4: the middle estimate sits 1.0-fold (0.00 log units) above what was measured, within the range that was stated.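

On the second core, the same swap of 4-hydroxy-3-methoxyphenyl for 4-methoxyphenyl gives a step (a 1.0-fold higher number from compound 3 to compound 4 (0.02 log units; within the scatter)) that lies within the scatter, as did the step on the first core (a 1.0-fold higher number from compound 1 to compound 2 (0.02 log units; within the scatter)), so in this assay neither pair can be told apart. This shows that the swap behaves alike on these two cores, in the limited sense that it produces no readable difference on either, but it does not show that a measurable effect carries from one core to another, since two steps lost in the scatter offer no real size to compare, and two cores are too few to support a rule for other cores. Nothing available here offers a reason for this result.

The compounds shown leave open whether a phenyl ring carrying a different group, such as a carboxylic acid or an amine, in place of 4-methoxyphenyl on a carbon with a double bond to nitrogen would give a step beyond the scatter in this assay. They also leave open how a longer chain in the core would read, and whether any such step would then carry from one core to the other.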